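Three measured ester and ether side chains, one to estimate

The source may report more compounds than this note shows. Statements on the series, on what has been measured and on what is new or still open speak of the compounds shown alone.

Measured so far:
compound 1, `CCC(C)(O)CC(=O)O[C@H](CC=C(C)C)C1=CC(=O)c2c(O)ccc(O)c2C1=O`: 25200 nM
compound 2, `CC(C)=CC[C@@H](OC[C@@H](C)O)C1=CC(=O)c2c(O)ccc(O)c2C1=O`: 22500 nM
compound 3, `CC(C)=CC[C@@H](OC[C@H](C)O)C1=CC(=O)c2c(O)ccc(O)c2C1=O`: 40300 nM

In a functional assay on HeLa cells (Homo sapiens) for cytotoxicity, read by MTT assay (a lower number here means a stronger inhibitor, a higher number a weaker inhibitor), compound 1 gives 25200 nM. Compound 2 gives 22500 nM. Compound 3 gives 40300 nM. All three numbers sit within the scatter of one another, so no order among them can be read. Compound 1 stands in the middle of the three in this sense: its nearest neighbour in number is reached by a 1.1-fold lower number from compound 1 to compound 2 (0.05 log units; within the scatter), its furthest by a 1.6-fold higher number from compound 1 to compound 3 (0.20 log units; within the scatter). Compounds 2 and 3 themselves are separated by a 1.8-fold higher number from compound 2 to compound 3 (0.25 log units; within the scatter), a step that rests only on (the fact that compounds 2 and 3 differ only in the configuration as drawn).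

Compound 4, `CC(C)=CC[C@@H](OC(=O)C1CCCO1)C1=CC(=O)c2c(O)ccc(O)c2C1=O`, differs from compound 1 as follows: oxolan-2-yl in place of 2-hydroxy-2-methylbutyl on a carbonyl carbon. Among the compounds with values here, the steps that bear on this change are those from compound 1 to compounds 2 and 3, which also replace the group carried on the oxygen on the saturated carbon; both stayed within the scatter. The change to compound 4 keeps the carbonyl and alters only the group beyond it, a smaller alteration than either of those. In this assay, therefore, no step beyond the scatter is expected, in either direction: the estimate amounts to a 1.0-fold higher number from compound 1 to compound 4 (0.01 log units; within the scatter). Compound 4 is estimated at 26000 nM, with a range from 11000 nM to 60000 nM.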

Compound 4, half-maximal inhibitory concentration: 17000 nM
Beside the measured number, compound 4's estimate is 1.5-fold (0.18 log units) above it, and the stated range covers the measured number.
By their numbers in this assay, from the lowest: compounds 4, 2, 1 and 3 (each within the scatter of the next, the first and the last beyond it).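

In this assay, 2-hydroxy-2-methylbutyl on the carbonyl carbon gives way to oxolan-2-yl, a ring with 0 hydrogen-bond donors, and the change reads as a 1.5-fold lower number from compound 1 to compound 4 (0.17 log units; within the scatter), so for this pair the open chain and its hydrogen-bond donor are not required to keep the number in this range. Set against the two ethers, the ester of compound 4 gives two different readings: a 1.3-fold lower number from compound 2 to compound 4 (0.12 log units; within the scatter), and a 2.4-fold lower number from compound 3 to compound 4 (0.37 log units; beyond the scatter), the only step in the series that clears the scatter, and a modest one. That step appears against only one of the two ether partners, so it does not establish a general separation of this ester from the ethers, and those two partners differ at a single stereocentre: the fact that compounds 2 and 3 differ only in the configuration as drawn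

The change from compound 1 to compound 4 swaps the open chain for a ring and removes the hydrogen-bond donor at once, and an unbranched butyl chain on the same carbonyl carbon would help to separate those two differences. From the compounds shown here alone, how an amine or a carboxylic acid carried on that chain would read in this assay stays open, as does the role of configuration in the oxolan-2-yl group, which is drawn without one.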